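A few compounds are considered here, and "the series" means these few. Any claim that something is new, unique, unknown or untested is made for them only; others in the source may bear on it.

Among the compounds with values here, in a functional assay on HepG2 cells (Homo sapiens) for inhibition, read by MTT assay, with a stated time of 72 h (on this read-out higher numbers stand for weaker inhibition and lower numbers for stronger inhibition), compound 1 (`O=[N+]([O-])c1ccc(-c2nnc(SCCCN3CCN(c4nc5ccccc5o4)CC3)o2)cc1`) gives 67200 nM and compound 2 (`O=C(NCc1nnc(SCCCN2CCN(c3nc4ccccc4o3)CC2)o1)c1ccccc1`) gives 88900 nM as the only other measured number, so the two lie within the scatter of each other. Compound 3 (`O=[N+]([O-])c1ccc(-c2nnc(SCCCN3CCN(c4nc5ccccc5s4)CC3)o2)cc1`) has 1,3-benzothiazol-2-yl in place of 1,3-benzoxazol-2-yl on an amine nitrogen in a ring. Within the data shown here, the one measured step (a 1.3-fold higher number from compound 1 to compound 2 (0.12 log units; within the scatter)) lies at another place, on an aromatic carbon, and no measured step covers this exchange. No step beyond the scatter is therefore expected in this assay and the expected step (a 1.2-fold lower number from compound 1 to compound 3 (0.09 log units; within the scatter)) is small. For compound 3 the estimate is 55000 nM with an expected range of 20000 nM to 130000 nM as the working figure.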

Compound 3, half-maximal inhibitory concentration: 93300 nM
Beside the measured number, compound 3's estimate is 1.7-fold (0.23 log units) below it, and the stated range covers the measured number.
By their numbers in this assay, from the lowest: compounds 1, 2 and 3 (each within the scatter of the next).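

In this assay, within the data shown here, this is the first measured exchange on the amine nitrogen in a ring, and it gives a 1.4-fold higher number from compound 1 to compound 3 (0.14 log units; within the scatter). With 4-nitrophenyl held fixed, 1,3-benzothiazol-2-yl and 1,3-benzoxazol-2-yl are therefore not told apart at this position in this assay. No measurement bearing on the reason for this result is available.

Going by these compounds, whether the exchange gives the same result with benzamidomethyl on the aromatic carbon remains open. Also open, on these data alone, is whether a carboxylic acid or an amine at that carbon, or a longer chain, would give a step beyond the scatter.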